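The source may hold more compounds than are shown below. What is called first, only, known or untested is meant among the compounds shown, and "the series" means these compounds.

Measured so far in a functional assay on the whole organism (strain Wistar) for inhibition, with Rattus norvegicus as the target, read by paw edema, at a dose of 100 mg/kg by the oral route; on this read-out lower numbers stand for less inhibition and higher numbers for more inhibition at the one dose given (going by the name of the read-out):
compound 1 `O=C(O)CNc1nc(-c2ccccc2)nc2ccccc12` gives 0%;
compound 2 `C[C@H](Nc1nc(-c2ccccc2)nc2ccc(I)cc12)C(=O)O` gives 6.5%;
compound 3 `CC[C@H](C)[C@H](Nc1nc(-c2ccccc2)nc2ccccc12)C(=O)O` gives 4.1%.

Compound 3 stands second highest of the three numbers, nearest to compound 2 and furthest from compound 1, with both gaps within the scatter. Among the compounds with values here, the only counted step, a number 4.1 percentage points higher from compound 1 to compound 3 (within the scatter), concerns a different change and is itself within the scatter. Compound 4 `CC[C@H](C)[C@H](Nc1nc(-c2ccccc2)nc2ccc(I)cc12)C(=O)O` differs from compound 3 by iodo in place of hydrogen on an aromatic carbon. Within the data shown here, no measured step isolates this change; compound 2 carries the same iodo together with a second difference from compound 1, and the two values lie within the scatter of each other. In this assay nothing beyond the scatter is therefore expected. For compound 4 the expected step is a number 0.9 percentage points higher from compound 3 to compound 4 (within the scatter). Compound 4 is estimated at 5%, with a range from 0% to 15%.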

Compound 4, a percentage reported as inhibition, in the whole organism at one dose (the size of the read-out at that dose, not a potency): 0%
For compound 4 the middle estimate is 5 percentage points above the measured one; the range from low to high includes it.
By their numbers in this assay, from the lowest: compounds 1, 4, 3 and 2 (each within the scatter of the next).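

In this assay, iodo in place of hydrogen on the aromatic carbon now has a step of its own (a number 4.1 percentage points lower from compound 3 to compound 4 (within the scatter)), so at this position, with sec-butyl on the chain, the change stays within the scatter. Sec-butyl in place of methyl, read with iodo present (a number 6.5 percentage points lower from compound 2 to compound 4 (within the scatter)), also stays within the scatter. No outside evidence bears on these readings. Open, on these data alone, is whether fluoro or methoxy on this aromatic carbon would read any differently. Also open, as far as these compounds go, is whether an amide in place of the carboxylic acid would leave the scatter.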